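The source may report more compounds than this note shows. Statements on the series, on what has been measured and on what is new or still open speak of the compounds shown alone.

Compound 1 `CCCCCCCCCCCCNc1nc(=O)c2c(ncn2[C@H]2C[C@H](O)[C@@H](CO)O2)c(=O)[nH]1` was tested in an assay on isolated protein for inhibition of ATP-dependent RNA helicase SUPV3L1, mitochondrial (Homo sapiens); on this read-out lower numbers stand for stronger inhibition and higher numbers for weaker inhibition. In this assay compound 1 gives > 500 ug/mL, which is a limit of the assay rather than a number. In this assay compound 2 `CCCCCCCCCCNc1nc(=O)c2ncn([C@@H]3O[C@H](CO)[C@@H](O)[C@H]3O)c2c(=O)[nH]1` gives 500 ug/mL. Compound 1 therefore stands at the limit of > 500 ug/mL in this assay, at which 1 of the 2 values shown sits. Compound 3 `CCCCCCCCCCCCNc1nc(=O)c2c(ncn2[C@@H]2C[C@H](O)[C@@H](CO)O2)c(=O)[nH]1` has not yet been measured. The change from compound 1 to compound 3 is the two compounds have the same atoms and bonds and differ only in configuration as drawn: 1 of 3 stereo elements differ; a stereocentre at a saturated ring carbon is drawn R in compound 1 and S in compound 3. For the measured compounds named here, no step between measured compounds is known here. The step is expected to lie within the scatter, as a number no higher from compound 1 to compound 3 (the limit leaves the size open). Compound 3 is expected to show 500 ug/mL, within a range from 200 ug/mL to 2000 ug/mL, and most likely again only a limit.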

Compound 3, half-maximal inhibitory concentration: 150 ug/mL
Estimate against measurement, compound 3: 3.3-fold (0.52 log units) above, and the stated range ends above it.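

Changing only the configuration at one saturated ring carbon, from R to S, gives an at least 3.3-fold lower number from compound 1 to compound 3 (0.52 log units; beyond the scatter) in this assay. Unlike the earlier pair, this comparison isolates a single change, so the shift can be traced to that one stereocentre: the fact that compounds 1 and 3 differ only in the configuration as drawn Compound 1 gives > 500 ug/mL, which is a limit of the assay and not a number.

Going by these compounds, it remains open whether the S configuration keeps this advantage when the chain on the shared core is replaced by a longer chain or by one carrying a carboxylic acid. On these data alone, the effect of changing the other two stereo elements also remains unknown.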